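Adding a Methoxy Group to the Strongest Thiourea

This account rests on a few compounds, and the source may have more. Where it says the series, first, only, none or still open, it means among the compounds named here.

Three thioureas have so far been examined in an assay on membranes from brain for binding affinity to Lysophosphatidylserine lipase ABHD12 (Mus musculus), read by fluorescence, with a stated time of 20 min, tested at 2 uM; on this read-out higher numbers stand for a stronger effect at the one concentration tested and lower numbers for a weaker effect. Compound 1, `FC(F)(F)c1cnc(NCCCCNC(=S)Nc2cccnc2)c(Cl)c1`, carries a flexible four-carbon chain and gives 12%. Compound 3, `FC(F)(F)c1cnc(N2CCCC(NC(=S)Nc3cccnc3)CC2)c(Cl)c1`, holds a seven-membered ring and gives 9%. Compound 2, `FC(F)(F)c1cnc(N2CCC(NC(=S)Nc3cccnc3)CC2)c(Cl)c1`, with a six-membered ring between its two ends, gives 89%. Compound 2 therefore stands highest of the three, and its distance to both compound 1 and compound 3 lies well beyond the usual scatter of this assay. How the change from one ring size or chain to another produces these gaps is not given here; only the three numbers themselves are known.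

Compound 4, `COc1ccc(NC(=S)NC2CCN(c3ncc(C(F)(F)F)cc3Cl)CC2)cn1`, keeps the whole of compound 2 and adds one small group: methoxy in place of hydrogen on an aromatic carbon. The pyridin-3-yl end of compound 2 thus becomes a 6-methoxypyridin-3-yl end in compound 4. Among the compounds with values here, no measured pair shows what such an addition does in this assay. Since the rest of the molecule matches compound 2 exactly, the step of a number 9 percentage points lower from compound 2 to compound 4 (within the scatter) is expected to be small, staying within the scatter or falling only slightly. Compound 4 is accordingly estimated at 80%, with a likely range from 55% to 95%.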

Compound 4, a percentage reported as inhibition, at one concentration (the size of the read-out at that concentration, not a potency): 0%
Compound 4: the middle estimate sits 80 percentage points above what was measured; measured number outside the range, below it.
By their numbers in this assay, from the lowest: compounds 4, 3 and 1 (each within the scatter of the next, the first and the last beyond it); then compound 2.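

Compound 1, compound 2 and compound 3 share the pyridin-3-yl end and differ only in the part linking it to the rest of the molecule, so they said nothing about that end; in this assay, methoxy in place of hydrogen there gives a number 89 percentage points lower from compound 2 to compound 4 (beyond the scatter). This shows that the carbon next to the ring nitrogen, para to a large group, is a sensitive position: adding only 2 heavy atoms there removes the whole effect seen at the one concentration tested, even with the six-membered ring of compound 2 kept intact. No measurement shown here explains this loss.

As far as these compounds go, it remains open whether the loss belongs to methoxy in particular or would follow from any group at this carbon, a question that smaller or different replacements such as fluorine, methyl or an amine could help to answer. It is also open whether the other carbons of this ring respond in the same way, since only one position on it has been changed among these compounds.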